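From methyl to cyclohexyl on the shared core

The compounds below may be only part of what the source reports. "The series", "measured", "known", "first", "only" and "open" are said of these compounds alone.

Measured so far in an ADME assay on microsomes from liver (Mus musculus, strain CD1) for metabolic stability, read by HPLC, with a stated time of 30 min, tested at 1 uM; on this read-out lower numbers stand for slow clearance and higher numbers for fast clearance:
Compound 1 `O=S(=O)(Nc1c(N2CCCC2)ccc2ncccc12)c1ccc(Br)cc1` gives 27 mL.min-1.g-1
Compound 2 `Cn1cc2c(NS(=O)(=O)c3ccc(Br)cc3)c(N3CCCC3)ccc2n1` gives 33 mL.min-1.g-1
Compound 3 `Cc1ccc2ncccc2c1NS(=O)(=O)c1ccc(Br)cc1` gives 3.6 mL.min-1.g-1

Compound 3 stands lowest of the three at 3.6 mL.min-1.g-1 in this assay and lies beyond the scatter of both others. Compound 4 `O=S(=O)(Nc1c(C2CCCCC2)ccc2ncccc12)c1ccc(Br)cc1` has cyclohexyl in place of methyl on an aromatic carbon and has not yet been measured. Among the measured compounds shown here, one measured step bears on this change. It is a 7.5-fold lower number from compound 1 to compound 3 (0.88 log units; beyond the scatter) and it lies beyond the scatter, with methyl in place of pyrrolidin-1-yl on an aromatic carbon. Read in reverse, that step has a ring replacing methyl and the number rising. Compound 2 also carries pyrrolidin-1-yl and stands at 33 mL.min-1.g-1 on a different core. For the measured compounds named here, no measured compound carries cyclohexyl, so this guide is imperfect. A rise of similar size is still the likeliest outcome, and the expected change is an 8.3-fold higher number from compound 3 to compound 4 (0.92 log units; beyond the scatter) in this assay as an estimate. For compound 4 the estimated value is 30 mL.min-1.g-1 with an expected range of 11 mL.min-1.g-1 to 80 mL.min-1.g-1 in this read-out.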

Compound 4, intrinsic clearance in microsomes: 38 mL.min-1.g-1
The estimate for compound 4 lay 1.3-fold (0.10 log units) below the measured number, within the range that was stated.
By their numbers in this assay, from the lowest: compound 3; then compounds 1, 2 and 4 (each within the scatter of the next).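

In this assay the change from methyl to cyclohexyl on this aromatic carbon is a large one (an 11-fold higher number from compound 3 to compound 4 (1.02 log units; beyond the scatter)), so a high number at this position no longer rests on pyrrolidin-1-yl alone. The swap of one ring for the other lies within the scatter (a 1.4-fold higher number from compound 1 to compound 4 (0.15 log units; within the scatter)), which means that the two rings cannot be told apart in this read-out and that the ring nitrogen of pyrrolidin-1-yl is not needed for a number of this size. No measurement shown here explains the rise.

Still open, as far as these compounds go, is how the number behaves with groups that lie between methyl and these rings, such as an ethyl or isopropyl chain. It is also unclear whether a ring carrying an added oxygen, such as morpholin-4-yl, would stand with the two rings or nearer to methyl.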